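Replacing the Sulfamoyl Group with a 2-Hydroxyethyl Chain

This account rests on a few compounds, and the source may have more. Where it says the series, first, only, none or still open, it means among the compounds named here.

Compound 1 `O=C(NC1CCCCC1)Oc1cccc(-c2cccc(Oc3ccccc3)c2)c1`: 420 nM
Compound 2 `O=C(NC1CCCCC1)Oc1cccc(-c2cccc(Cc3ccccc3)c2)c1`: 1860 nM
Compound 3 `NS(=O)(=O)c1cccc(-c2cccc(OC(=O)NC3CCCCC3)c2)c1`: 26.5 nM

Of the compounds shown here, three sharing one carbamate core have been tested in an assay on cell membranes for binding affinity to Fatty-acid amide hydrolase 1 (Rattus norvegicus); on this read-out higher numbers stand for weaker inhibition and lower numbers for stronger inhibition. Compound 3 stands lowest of the three, and the nearest to it is compound 1, with a 16-fold lower number from compound 1 to compound 3 (1.20 log units; beyond the scatter) separating them; compound 2 lies furthest away, with a 70-fold lower number from compound 2 to compound 3 (1.85 log units; beyond the scatter) between them. The change from compound 1 to compound 2, a 4.4-fold higher number from compound 1 to compound 2 (0.65 log units; beyond the scatter), shows that even a swap between two bulky groups at this position shifts the number beyond the scatter.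

Compound 4 `O=C(NC1CCCCC1)Oc1cccc(-c2cccc(CCO)c2)c1` has not yet been measured. It differs from compound 3 by 2-hydroxyethyl in place of sulfamoyl on an aromatic carbon. All three measured steps bear on this position, and each was beyond the scatter, so a step beyond the scatter is expected here too. Since the sulfamoyl group of compound 3 gave the strongest result, 26.5 nM, its removal is expected to weaken binding, by roughly a 7.5-fold higher number from compound 3 to compound 4 (0.88 log units; beyond the scatter). Compound 4 is therefore estimated at 200 nM, within a range of 60 nM to 700 nM.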

Compound 4, half-maximal inhibitory concentration: 18.7 nM
Compound 4: the middle estimate sits 11-fold (1.03 log units) above what was measured; the measured number lies below the stated range.
By their numbers in this assay, from the lowest: compounds 4 and 3 (each within the scatter of the next); then compound 1; then compound 2.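

In this assay, a group containing sulfur proves unnecessary at this position: the step with 2-hydroxyethyl in place of sulfamoyl is a 1.4-fold lower number from compound 3 to compound 4 (0.15 log units; within the scatter) and leaves the two groups indistinguishable. The gains over the ring-bearing compounds are large, with a 22-fold lower number from compound 1 to compound 4 (1.35 log units; beyond the scatter) for 2-hydroxyethyl in place of phenoxy, and a 99-fold lower number from compound 2 to compound 4 (2.00 log units; beyond the scatter) for hydroxymethyl in place of phenyl on the chain. Across these four compounds, the two groups without a ring give the lower numbers and phenoxy and benzyl the higher ones, with no compound going against this.

As far as these compounds go, whether the hydroxyl of the chain matters remains open, and a plain ethyl group, a 2-methoxyethyl group, an amine or a longer chain ending in hydroxyl would test that. Nothing measured here explains why sulfamoyl and 2-hydroxyethyl give such similar numbers.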